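From acetamido to ethylamino at the assay limit

A few compounds are considered here, and "the series" means these few. Any claim that something is new, unique, unknown or untested is made for them only; others in the source may bear on it.

In a functional assay on HeLa cells (Homo sapiens) for antiproliferative activity, read by MTT assay, with a stated time of 48 h (a lower number here means a stronger inhibitor, a higher number a weaker inhibitor), compound 1 `CC(=O)Nc1nccc2ncc(-c3cnn(C)c3)cc12` gives > 50000 nM, which is a limit and not a number. Compound 2 `Cn1cc(-c2cnc3ccnc(NC(=O)c4ccc(F)cc4)c3c2)cn1` gives > 50000 nM, again a limit. Compound 3 `COc1ccc(C(=O)Nc2nccc3ncc(-c4cnn(C)c4)cc23)cc1` gives > 50000 nM, also a limit. The measured compounds thus stand together at the limit of > 50000 nM in this assay, at which 3 of the 3 values shown sit. Compound 4 `CCNc1nccc2ncc(-c3cnn(C)c3)cc12` carries ethyl in place of the acetyl of compound 1, on a nitrogen on an aromatic ring: ethyl in place of acetyl on a nitrogen on an aromatic ring. The nearest measured changes are a step that the two limits leave unreadable from compound 1 to compound 2 and a step that the two limits leave unreadable from compound 1 to compound 3, and neither offers a size to build on. The expected step is therefore a number no higher from compound 1 to compound 4 (the limit leaves the size open), with no direction expected. Compound 4 is estimated at 50000 nM, with an expected range from 15000 nM to 100000 nM.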

Compound 4, half-maximal inhibitory concentration: > 50000 nM
Compound 4 gave a limit, no number (the forecaster's own chance of this, stated with the estimate: 75%); the middle value sits exactly at the limit.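

No step can be read between compound 1 and compound 4, or among compounds 1 to 4, in this assay, as each gives only a limit: the limit of > 50000 nM in this assay, at which 4 of the 4 values shown sit. As far as these compounds go, whether ethyl or acetyl makes any difference to activity stays open.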